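The compounds below may be only part of what the source reports. "The series", "measured", "known", "first", "only" and "open" are said of these compounds alone.

Compound 1 `O=C(NN=C(c1ccccn1)c1ccccn1)c1ccc([N+](=O)[O-])cc1` gives the lowest of the two numbers recorded in an ADME assay on cells (Homo sapiens) for antiproliferative activity, read by MTT assay (a lower number here means a stronger inhibitor, a higher number a weaker inhibitor), namely 260 nM. The other measured compound, compound 2 `C/C(=N\NC(=O)c1ccc([N+](=O)[O-])cc1)c1cnccn1`, gives 1390 nM in this assay, a gap that lies beyond the scatter. Compound 3 `O=C(NN=C(c1ccccn1)c1ccccn1)c1ccc(Br)cc1` differs from compound 1 by bromo in place of nitro on an aromatic carbon. For the measured compounds named here, no measured pair shows this exchange, so its size is not known from these data. A small step, perhaps a slight loss, is expected as a 1.5-fold higher number from compound 1 to compound 3 (0.19 log units; within the scatter). Compound 3 is therefore estimated at 400 nM in this assay, within 120 nM to 1300 nM.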

Compound 3, half-maximal inhibitory concentration: 300 nM
For compound 3 the middle estimate is 1.3-fold (0.12 log units) above the measured one; the measured number falls inside the stated range.
By their numbers in this assay, from the lowest: compounds 1 and 3 (each within the scatter of the next); then compound 2.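

In this assay, the step at this aromatic carbon, para to a large group, is a 1.2-fold higher number from compound 1 to compound 3 (0.06 log units; within the scatter), so the two compounds cannot be told apart. On the core of compound 1, the nitro group, with its hydrogen-bond acceptors, can therefore give way to bromo, which has none, without a change beyond the scatter. Nothing available explains this result.

As far as these compounds go, whether an amine, a methoxy group or a carboxylic acid would be accepted at this position remains open. So does whether the same exchange would hold on the core of compound 2.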